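Series notes: ethyl in place of fluoro, compound 1 to compound 4

The compounds below may be only part of what the source reports. "The series", "measured", "known", "first", "only" and "open" are said of these compounds alone.

Measured so far:
compound 1 `Nc1ccccc1NC(=O)/C=C/c1ccc(CSc2ccc(F)cc2)cc1` gives 28.8%
compound 2 `Nc1ccccc1NC(=O)c1ccc(CSc2ccc(C(F)(F)F)cn2)cc1` gives 4.3%
compound 3 `Cc1ccc(SCc2ccc(C(=O)Nc3ccccc3N)cc2)cc1` gives 17.5%

Three compounds have been run in a functional assay on A-375 cells (Homo sapiens) for inhibition, read by CCK-8 assay, with a stated time of 72 h, tested at 2 uM; a lower number here means less inhibition of growth, a higher number more inhibition of growth at the concentration tested. Compound 1 stands highest of the three numbers. The nearest value is that of compound 3, which lies lower by a margin beyond the usual scatter; compound 2 lies further below, again beyond the scatter. No two of these compounds differ in a single place, so no step between measured compounds can be isolated, and what the pairs show is only the gaps between their numbers.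

Compound 4 `CCc1ccc(SCc2ccc(/C=C/C(=O)Nc3ccccc3N)cc2)cc1` is the next candidate. Compared with compound 1 the change is ethyl in place of fluoro on an aromatic carbon. For the measured compounds named here, nothing among the measured compounds isolates this change: compound 3 carries a methyl group, but it also differs from compound 1 in its core, so its value cannot be read as a guide to the ethyl-for-fluoro exchange alone.

Given the absence of a measured step of this kind, the step from compound 1 to compound 4 is expected to stay within the scatter, a number 3.8 percentage points lower from compound 1 to compound 4 (within the scatter). On that basis compound 4 is estimated at 25% in this assay, with an expected range from 10% to 42%.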

Compound 4, percent growth inhibition at one concentration: 5.27%
Compound 4: middle estimate off by 19.7 percentage points, on the high side; the whole stated range lies above it.
By their numbers in this assay, from the lowest: compounds 2 and 4 (each within the scatter of the next); then compound 3; then compound 1.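

In this assay, for the compounds shown here, exchanging 4-fluorophenyl for 4-ethylphenyl gives a number 23.5 percentage points lower from compound 1 to compound 4 (beyond the scatter) and is the only change between these two structures, so this site on the core of compound 1 is sensitive to what it carries. Going by these compounds alone, this is the first single-place step; the earlier compounds offered only gaps between structures that differ in more than one place, and none of those gaps could be assigned to this site. The step is one pair and defines no trend across substituents, and nothing available bears on the reason for it.

As far as these compounds go, whether an amine, a carboxylic acid or a longer chain such as propyl at this same place on the core of compound 1 would track with the ethyl compound or with the fluoro compound remains open. From the compounds shown here alone, whether the exchange of fluoro for ethyl would have a comparable effect on the core of compound 3 also remains open.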